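Acetylation of the ring amine: expected shift in potency

This account rests on a few compounds, and the source may have more. Where it says the series, first, only, none or still open, it means among the compounds named here.

compound 1 `CCCn1c(=O)c2nc(C3CCC(C(=O)OC)CC3)[nH]c2n(CCC)c1=O`: 130 nM
compound 2 `CCCn1c(=O)c2nc(C3CCCC(N)C3)[nH]c2n(CCC)c1=O`: 50 nM

Of the compounds shown here, two have been measured in a functional assay for antagonist activity at adenosine receptor A1 (Homo sapiens); on this read-out higher numbers stand for weaker inhibition and lower numbers for stronger inhibition. Compound 1 `CCCn1c(=O)c2nc(C3CCC(C(=O)OC)CC3)[nH]c2n(CCC)c1=O` gives 130 nM. Compound 2 `CCCn1c(=O)c2nc(C3CCCC(N)C3)[nH]c2n(CCC)c1=O` gives 50 nM, the lowest of the two numbers, and its gap to compound 1 lies beyond the usual scatter. For the measured compounds named here, the two compounds differ in more than one place, so no single step between them can be read off.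

Compound 3 `CCCn1c(=O)c2nc(C3CCCC(NC(C)=O)C3)[nH]c2n(CCC)c1=O` is not yet measured. Relative to compound 2 the change is acetyl in place of hydrogen on an amine nitrogen. Going by the values given here, no measured pair shows the effect of such a change, so the direction has to be judged from the two values at hand alone: the only other substituent pattern on the saturated ring, that of compound 1 with 130 nM, sits higher than compound 2. A moderate rise toward that number is expected, a 2.2-fold higher number from compound 2 to compound 3 (0.34 log units; beyond the scatter), with the step likely to reach just beyond the scatter. Compound 3 is therefore estimated at 110 nM, within a range of 35 nM to 350 nM.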

Compound 3, inhibition constant: 41 nM
For compound 3 the middle estimate is 2.7-fold (0.43 log units) above the measured one; low and high end bracket the measured number.
By their numbers in this assay, from the lowest: compounds 3 and 2 (each within the scatter of the next); then compound 1.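

In this assay, for the compounds shown here, the change from amino to acetamido gives the first step that can be read in one place (a 1.2-fold lower number from compound 2 to compound 3 (0.09 log units; within the scatter)). On the amine nitrogen whose other neighbour is a saturated ring carbon, acetyl in place of hydrogen therefore leaves the read-out within the scatter, so at this position the free amine of compound 2 and the acetamido group of compound 3 cannot be told apart on this read-out. No measured evidence on any property of either group bears on this step, and the result gives no reason for it.

Compound 1 differs from compound 2 and compound 3 in more than one place, so the steps to it cannot be read, and the contribution of its methyl ester stays separate from anything seen at the nitrogen. The compounds shown leave open whether a longer acyl chain, a methyl group or a sulfonyl group on the same nitrogen would also stay within the scatter of compound 2, and what a carboxylic acid would do on the saturated ring.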